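A Methyl Added to the Core of Compound 2

The source may report more compounds than this note shows. Statements on the series, on what has been measured and on what is new or still open speak of the compounds shown alone.

Measured in a functional assay on HepG2 cells (Homo sapiens) for antiproliferative activity, read by MTT assay, with a stated time of 72 h; a higher number here means a weaker inhibitor, a lower number a stronger inhibitor:
compound 1 `CC/C=C\C(=O)Nc1cc(Nc2nccc(-c3cn(C)c4ccc(F)cc34)n2)c(OC)cc1N(C)CCN(C)C` gives 5290 nM
compound 2 `CCC/C=C\C(=O)Nc1cc(Nc2nccc(-c3cn(C)c4ccc(F)cc34)n2)c(OC)cc1N(C)CCN(C)C` gives 3400 nM
compound 3 `CCC/C=C\C(=O)Nc1cc(Nc2ncc(C#N)c(-c3cn(C)c4ccc(F)cc34)n2)c(OC)cc1N(C)CCN(C)C` gives 2010 nM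

Compound 2 holds the second highest of the three numbers, yet its steps to compound 1 and to compound 3 both fall within the usual scatter, so the three cannot be told apart. Compound 4 `CCC/C=C\C(=O)Nc1cc(Nc2nc(C)cc(-c3cn(C)c4ccc(F)cc34)n2)c(OC)cc1N(C)CCN(C)C` differs from compound 2 by methyl in place of hydrogen on an aromatic carbon, next to the ring nitrogen and meta to the 5-fluoro-1-methyl-1H-indol-3-yl group. Among the measured compounds shown here, two measured steps bear on this: a 1.6-fold lower number from compound 1 to compound 2 (0.19 log units; within the scatter), a methyl added on the chain, and a 1.7-fold lower number from compound 2 to compound 3 (0.23 log units; within the scatter), a small group on an aromatic carbon of the shared core. Neither left the scatter, so no step beyond the scatter is expected in this assay; the expected step is no change at the digits printed from compound 2 to compound 4 (within the scatter). Compound 4 is estimated at 3400 nM, within 1200 nM to 9500 nM.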

Compound 4, half-maximal inhibitory concentration: 12100 nM
Estimate against measurement, compound 4: 3.6-fold (0.55 log units) below, outside the stated range (above it).
By their numbers in this assay, from the lowest: compounds 3, 2 and 1 (each within the scatter of the next, the first and the last beyond it); then compound 4.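

In this assay, methyl in place of hydrogen on the aromatic carbon next to the ring nitrogen gives a 3.6-fold higher number from compound 2 to compound 4 (0.55 log units; beyond the scatter) and so marks a weaker inhibitor. Among the compounds shown here, this is the first step to leave the scatter, so this carbon of the shared core responds to a single added methyl, while the methyl added on the chain between compound 1 and compound 2 did not move the number beyond the scatter. Nothing measured here explains the step. On these data alone, it remains open whether an amine or a fluorine atom on this same carbon would raise the number as methyl does.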